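A few compounds are considered here, and "the series" means these few. Any claim that something is new, unique, unknown or untested is made for them only; others in the source may bear on it.

Measured so far:
compound 1 `OC1CNCc2nc(-c3ccc(N4CCCC4)cc3)sc21` — 1530 nM
compound 2 `CN(C)c1ccc(-c2nc3c(s2)C(O)CCC3)c(CO)c1` — 360 nM
compound 3 `Cc1cc(N(C)C)ccc1-c1nc2c(s1)[C@@H](O)CCC2` — 2150 nM

All three were run in a functional assay on MCF7 cells (Homo sapiens) for cytotoxicity, read by sulforhodamine B assay, with a stated time of 2 days; on this read-out higher numbers stand for weaker inhibition and lower numbers for stronger inhibition. Compound 1 gives the second highest of the three numbers; compound 3 lies within the scatter of it, so the two are not separated, while compound 2 sits lower by a gap beyond the scatter. Compound 4 `CN(C)c1ccc(-c2nc3c(s2)C(O)CNC3)cc1` has not been measured. It differs from compound 1 in one place: dimethylamino in place of pyrrolidin-1-yl on an aromatic carbon. Among the compounds with values here, no measured pair differs by this change alone, and the two dimethylamino compounds, compound 2 and compound 3, carry cores and substituents unlike those of compound 1, so they do not anchor the step. The expectation is a small step, a 1.2-fold lower number from compound 1 to compound 4 (0.07 log units; within the scatter), in no firm direction and not beyond the scatter. Compound 4 is therefore estimated at 1300 nM, within 450 nM to 3800 nM.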

Compound 4, half-maximal inhibitory concentration: 1600 nM
Compound 4: the middle estimate sits 1.2-fold (0.09 log units) below what was measured; low and high end bracket the measured number.
By their numbers in this assay, from the lowest: compound 2; then compounds 1, 4 and 3 (each within the scatter of the next).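

In this assay, within the data shown here, the swap of pyrrolidin-1-yl for dimethylamino on an aromatic carbon para to a large group gives a 1.0-fold higher number from compound 1 to compound 4 (0.02 log units; within the scatter) and is now read directly for the first time. On this core, the two groups are not separated, so the ring of pyrrolidin-1-yl is not required to keep the value of compound 1. No available measurement explains why the two groups read alike.

Going by these compounds, this is a single matched pair, so the same swap on other cores remains open. Also open, on these data alone, is whether morpholine, a primary amine or a carboxylic acid at this place would hold the value.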